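Ester to acetamide on the biaryl of compound 2

A few compounds are considered here, and "the series" means these few. Any claim that something is new, unique, unknown or untested is made for them only; others in the source may bear on it.

Measured compounds:
compound 1, `CCNS(=O)(=O)c1cccc(-c2ccc(OCC)cc2)c1`: 200000 nM
compound 2, `CCOc1ccc(-c2cccc(C(=O)OCCOC)c2)cc1`: 70000 nM

Of the compounds shown here, two have been measured in an assay on COS-7 cells for inhibition of patatin-like phospholipase domain-containing protein 2 (Mus musculus); a higher number here means a weaker inhibitor, a lower number a stronger inhibitor. Compound 1, `CCNS(=O)(=O)c1cccc(-c2ccc(OCC)cc2)c1`, gives 200000 nM in this assay. Within the data shown here, compound 2, `CCOc1ccc(-c2cccc(C(=O)OCCOC)c2)cc1`, gives 70000 nM, the lower of the two numbers, and the one step between them, a 2.9-fold lower number from compound 1 to compound 2 (0.46 log units; beyond the scatter), is a modest improvement beyond the scatter. Compound 3, `CCOc1ccc(-c2cccc(NC(C)=O)c2)cc1`, is not yet measured. It differs from compound 2 in one place: acetamido in place of (2-methoxyethoxy)carbonyl on an aromatic carbon. Among the measured compounds shown here, the only measured step, from ethylsulfamoyl to the ester, does not involve an acetamido group, so it gives no direct guide for this change; it shows only that swapping the group at this position moves the number by a modest amount. With a single weakly active pair as the basis, no step beyond the scatter is expected in either direction, and compound 3 is expected to remain weak in this assay, with the step of a 1.4-fold higher number from compound 2 to compound 3 (0.15 log units; within the scatter) as the estimated change. Compound 3 is therefore estimated at 100000 nM, in the range 30000 nM to 300000 nM.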

Compound 3, half-maximal inhibitory concentration: 200000 nM
Compound 3: middle estimate off by 2.0-fold (0.30 log units), on the low side; low and high end bracket the measured number.
By their numbers in this assay, from the lowest: compound 2; then compounds 1 and 3 (each within the scatter of the next).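

In this assay, acetamido does not keep the lower number seen with the (2-methoxyethoxy)carbonyl group on this aromatic carbon: the change gives a 2.9-fold higher number from compound 2 to compound 3 (0.46 log units; beyond the scatter), the first step shown away from the ester that starts from compound 2. Against the ethylsulfamoyl group, the same acetamido group gives no change at the digits printed from compound 1 to compound 3 (within the scatter), so among these three compounds the two groups that carry a nitrogen read alike, and only the ester, which has none, stands lower; no compound shown goes against this, but three compounds are a thin basis for any pattern. No measurement shown offers an explanation for this difference between the ester and the other two groups.

As far as these compounds go, whether the lower number of compound 2 belongs to the ester carbonyl or to its 2-methoxyethoxy chain stays open, and a methyl ester, a carboxylic acid or an amide with its carbonyl attached directly to the ring at this place would be needed to separate the two. From the compounds shown here alone, the ethoxy group is the same in all three compounds, so the effect of a methoxy group or a longer chain there is also open.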